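Removing the benzyl group from a partial agonist scaffold

The source may report more compounds than this note shows. Statements on the series, on what has been measured and on what is new or still open speak of the compounds shown alone.

Compounds measured so far:
Compound 1 `CCC(=O)NCC1CCc2ccccc2N1CC(=O)NC`: "not determined" (no result reported)
Compound 2 `CCNC(=O)NCC1CCc2ccccc2N1`: 30%
Compound 3 `CCC(=O)NCC1CCc2ccccc2N1Cc1ccccc1`: 42%

Three compounds sharing one core have been examined in a functional assay on CHO cells with melatonin receptor type 1A (Homo sapiens) as the target, read by GTPgammaS binding, with a stated time of 1 h; a higher number here means a larger maximal response, a lower number a smaller maximal response. Compound 1 carries no result in this assay. Compound 2 gives 30% in this assay. Compound 3 gives 42% in this assay, the higher of the two numbers available, and the gap to compound 2 lies beyond the usual scatter of repeated measurements. Within the data shown here, no pair among the measured compounds differs in only one place, so no single step can be read directly from the numbers.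

The next compound, compound 4 `CCC(=O)NCC1CCc2ccccc2N1`, is related to compound 3 by one change: hydrogen in place of benzyl on a nitrogen on an aromatic ring in a ring. Among the measured compounds shown here, compound 2, the only other compound with a number, also carries hydrogen on that nitrogen and shows the lower value, but it differs from compound 3 elsewhere as well, so this is a hint rather than a measured step. For compound 4 a modest decrease in this assay is expected, a step of a number 9 percentage points lower from compound 3 to compound 4 (within the scatter) that may or may not exceed the scatter. The estimated maximal response for compound 4 is 33%, within a range from 18% to 50%.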

Compound 4, largest response reached (Emax), in percent of the reference or control that the assay uses: 37%
The estimate for compound 4 lay 4 percentage points below the measured number, within the range that was stated.
By their numbers in this assay, from the lowest: compounds 2, 4 and 3 (each within the scatter of the next, the first and the last beyond it).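

In this assay, among these compounds, hydrogen in place of benzyl on a nitrogen on an aromatic ring in a ring gives the first directly measured step at this position, a number 5 percentage points lower from compound 3 to compound 4 (within the scatter). The benzyl group can therefore be removed from compound 3 without a shift in maximal response that stands clear of the usual scatter, so this assay does not show that the group is needed for the response. With hydrogen on that nitrogen, ethyl in place of ethylamino on a carbonyl carbon gives a number 7 percentage points higher from compound 2 to compound 4 (within the scatter), which means that each of the two single changes linking compound 4 to its neighbours stays within the scatter on its own. Nothing in the available data explains either step.

Going by these compounds, it remains open whether a different group on that nitrogen, such as a methyl, a phenethyl chain or a carboxylic acid on a short chain, would move the maximal response beyond the scatter. Also unresolved is how ethylamino in place of ethyl on the carbonyl carbon would read with benzyl still on the nitrogen, since the side chain has been compared here only with hydrogen in that place.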